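Chloro for methyl on the pyridine: an expected small step

This account rests on a few compounds, and the source may have more. Where it says the series, first, only, none or still open, it means among the compounds named here.

Compound 1, `C[C@@H](Oc1cc2ccn(CCC(=O)O)c2cc1Cl)c1ccccn1`, gives 2.17 in a physicochemical assay for lipophilicity, read by HPLC, at pH 7.4; a higher number here means a more lipophilic compound, a lower number a more polar compound.
Compound 2, `Cc1ccc([C@@H](C)Oc2cc3onc(CCC(=O)O)c3cc2Cl)nc1`, gives 2.42.
Compound 3, `O=C(O)CCn1c(=O)oc2cc(OCc3ccccc3)c(Cl)cc21`, gives 2.71.

Compound 2 sits within the usual scatter of both compound 1 and compound 3, so the three measured numbers are not separated from one another. Among the compounds with values here, no pair among them differs in only one place, so no single step has been measured.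

Compound 4, `C[C@@H](Oc1cc2onc(CCC(=O)O)c2cc1Cl)c1ccc(Cl)cn1`, is the unmeasured partner of compound 2. The difference between them is chloro in place of methyl on an aromatic carbon. Within the data shown here, with no measured step of this kind to lean on, only a small move is expected, if any, towards a higher number in this assay, a step of a number 0.13 log units higher from compound 2 to compound 4 (within the scatter) that need not exceed the scatter. Compound 4 is therefore estimated at 2.55, within 2.25 to 2.85.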

Compound 4, distribution coefficient: 2.91
Beside the measured number, compound 4's estimate is 0.36 log units below it; the whole stated range lies below it.
By their numbers in this assay, from the lowest: compounds 1, 2, 3 and 4 (each within the scatter of the next, the first and the last beyond it).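

In this assay, within the data shown here, chloro in place of methyl at this place, two atoms from the ring nitrogen, gives the first single step in the set, a number 0.49 log units higher from compound 2 to compound 4 (beyond the scatter). Among these compounds, the change from 5-methylpyridin-2-yl to 5-chloropyridin-2-yl therefore clears the scatter on this core, something the earlier compounds could not show, as no two of them differed in only one place. Nothing available explains the size of this step.

As far as these compounds go, how a nitrile or a methoxy group would read at this place remains open. So does whether the same exchange gives a similar step on the core of compound 1.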